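Replacing a Hydroxy Group with Ethyl on the Amino Diol

A few compounds are considered here, and "the series" means these few. Any claim that something is new, unique, unknown or untested is made for them only; others in the source may bear on it.

Measured compounds in a functional assay on HBL-100 cells (Homo sapiens) for antiproliferative activity, read by sulforhodamine B assay, with a stated time of 48 h; on this read-out higher numbers stand for weaker inhibition of growth and lower numbers for stronger inhibition of growth:
compound 1 `CCCCCCCCCCCCCCC[C@@H](O)[C@@H](N)[C@@H](C)O`: 21000 nM
compound 2 `CCCCCCCCCCCCCCC[C@@H](O)[C@H](C)N`: 2300 nM
compound 3 `CCCCCCCCC[C@@H](O)[C@@H](N)[C@@H](C)O`: 13000 nM

Compound 1 gives the highest of the three numbers in this assay; compound 3 lies nearest to it, compound 2 furthest. Compound 4 `CCCCCCCCCCCCCCC[C@@H](O)[C@@H](N)[C@@H](C)CC` differs from compound 1 by a single change: ethyl in place of hydroxy on a saturated chain carbon bound to two saturated chain carbons. Of the measured steps, only the change from compound 1 to compound 2 also removes this hydroxy group, and it gave a 9.1-fold lower number from compound 1 to compound 2 (0.96 log units; beyond the scatter). The step from compound 1 to compound 3 alters the chain far from the change and gave a 1.6-fold lower number from compound 1 to compound 3 (0.21 log units; within the scatter). Compound 4 is therefore expected to show a lower number than compound 1, roughly a 3.5-fold lower number from compound 1 to compound 4 (0.54 log units; beyond the scatter). The estimate for compound 4 is 6000 nM, between 2500 nM and 15000 nM.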

Compound 4, concentration for 50% growth inhibition: 2400 nM
The estimate for compound 4 lay 2.5-fold (0.40 log units) above the measured number; the whole stated range lies above it.
By their numbers in this assay, from the lowest: compounds 2 and 4 (each within the scatter of the next); then compounds 3 and 1 (each within the scatter of the next).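

In this assay, ethyl in place of hydroxy gave an 8.8-fold lower number from compound 1 to compound 4 (0.94 log units; beyond the scatter) with the rest of the core unchanged, so this single swap at the position is enough for a step beyond the scatter. Extending the carbon group at this site made no difference beyond the scatter, with a 1.0-fold higher number from compound 2 to compound 4 (0.02 log units; within the scatter) for sec-butyl in place of methyl. Nothing shown here accounts for this result. Open, on these data alone, is whether a methoxy group, a fluorine atom or an amine in place of hydroxy would match ethyl, and whether ethyl acts alike on the shorter chain of compound 3.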